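Swapping the Aryl Group on the Ring Nitrogen

The source may report more compounds than this note shows. Statements on the series, on what has been measured and on what is new or still open speak of the compounds shown alone.

Compound 1 `Cc1ccccc1-n1nc(C)c2c1NC(=O)[C@H](C)S[C@@H]2c1ccc(-c2ccoc2)cc1`: 40%
Compound 2 `COc1ccccc1-n1nc(C)c2c1NC(=O)[C@H](C)S[C@@H]2c1ccc(Oc2ccccc2)cc1`: 37%
Compound 3 `COc1ccc(C2SC(C)C(=O)Nc3c2c(C)nn3-c2ccccc2C)c(OC)c1`: 63%

The three compounds share one core and were measured in an assay on isolated protein for agonist activity at Bile acid receptor (Homo sapiens), read by AlphaScreen, with a stated time of 30 min; a lower number here means a smaller maximal response, a higher number a larger maximal response. Compound 2 gives 37%, the lowest of the three numbers. Compound 1 lies so close that the two values fall within the usual scatter, so no order between them can be read. Compound 3 stands clearly higher, beyond the scatter.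

Compound 4 `Cc1ccc(-n2nc(C)c3c2NC(=O)[C@H](C)S[C@@H]3c2ccc(Oc3ccccc3)cc2)cc1` has not yet been measured. It differs from compound 2 in one place: 4-methylphenyl in place of 2-methoxyphenyl on an aromatic nitrogen. Within the data shown here, no measured pair shows this exact exchange, so its effect is unknown. A modest shift, staying within the scatter, is expected; the estimated step is a number 5 percentage points higher from compound 2 to compound 4 (within the scatter). Compound 4 is therefore expected to reach 42%, with a range from 25% to 60%.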

Compound 4, largest response reached (reported as efficacy), in percent of the reference or control that the assay uses: 11%
For compound 4 the middle estimate is 31 percentage points above the measured one; the measured number lies below the stated range.
By their numbers in this assay, from the lowest: compound 4; then compounds 2 and 1 (each within the scatter of the next); then compound 3.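

The aryl group on this aromatic nitrogen is not a silent position: in this assay, 4-methylphenyl in place of 2-methoxyphenyl gives a clear change (a number 26 percentage points lower from compound 2 to compound 4 (beyond the scatter)). The earlier compounds shown here differ from one another in more than one place, so none of them isolated an exchange here. No supporting measurement explains this drop.

The compounds shown leave open whether the loss of the methoxy group or the new location of the substituent matters more. A 4-methoxyphenyl or a plain phenyl group on this nitrogen could help separate the two.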